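This account rests on a few compounds, and the source may have more. Where it says the series, first, only, none or still open, it means among the compounds named here.

Measured compounds, with their values in an ADME assay on L929 cells (Mus musculus) for cytotoxicity, read by resazurin assay, with a stated time of 48 h; a lower number here means that less compound is tolerated, a higher number that more compound is tolerated:
compound 1, `COC(=O)Cn1c2ccc([N+](=O)[O-])cc2c(=O)n1Cc1ccccc1`: 129000 nM.
compound 2, `N#CCn1c2ccc([N+](=O)[O-])cc2c(=O)n1Cc1ccccc1`: > 256000 nM, a limit of the assay and not a number.
compound 3, `CCOC(=O)CCCn1c2ccc([N+](=O)[O-])cc2c(=O)n1Cc1ccccc1`: 78100 nM.

Compound 2 sits at the limit of > 256000 nM in this assay, at which 1 of the 3 values shown sits; only a limit is known for it, with no number behind it. The steps around it: an at least 1.9-fold higher number from compound 1 to compound 2 (0.29 log units; that floor lies within the scatter); an at least 3.2-fold lower number from compound 2 to compound 3 (0.51 log units; beyond the scatter); and between the two esters, a 1.7-fold lower number from compound 1 to compound 3 (0.22 log units; within the scatter).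

Compound 4, `Cc1ccc(S(=O)(=O)n2c3ccc([N+](=O)[O-])cc3c(=O)n2Cc2ccccc2)cc1`, is not yet measured in this assay. Against compound 2 the change is (4-methylphenyl)sulfonyl in place of cyanomethyl on an aromatic nitrogen. Both measured departures from the cyanomethyl group, to methoxycarbonyl and to 2-(ethoxycarbonyl)ethyl, gave numbers rather than limits. For the measured compounds named here, no measured step touches a sulfonyl group or an aromatic ring at that aromatic nitrogen, so the direction rests on thin evidence. A lower number than the limit of compound 2 is expected for compound 4, the expected step being an at least 2.8-fold lower number from compound 2 to compound 4 (0.45 log units; beyond the scatter), though not a large one. Compound 4 is therefore estimated at 90000 nM, between 25000 nM and 256000 nM, with a fair chance that this assay again reports only a limit.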

Compound 4, concentration lethal to 50% of the cells: > 256000 nM
Compound 4 was reported as a limit (the forecaster's own chance of this, stated with the estimate: 25%); at least 2.8-fold (0.45 log units) between middle value and limit.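

In this assay compound 4 gives > 256000 nM, a limit of the assay and not a number, so this position accepts a (4-methylphenyl)sulfonyl group, with its six-membered aromatic ring, directly on the aromatic nitrogen without a measurable value appearing. Against the longer ester the change reads as an at least 3.2-fold higher number from compound 3 to compound 4 (0.51 log units; beyond the scatter), whereas against the shorter ester it reads as an at least 1.9-fold higher number from compound 1 to compound 4 (0.29 log units; that floor lies within the scatter), so only the first of these two comparisons separates the sulfonyl compound from an ester. The step between compound 2 and compound 4 cannot be read, and the nitrile and the sulfonyl group therefore stay unordered, with the top of the series resting on a shared limit: the limit of > 256000 nM in this assay, at which 2 of the 4 values shown sit.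

Still open, from the compounds shown here alone, is whether the aromatic ring or the sulfonyl group goes with the result at this nitrogen, a question that a methylsulfonyl or a benzoyl group on the same atom would address. Also open, going by these compounds, is how a carboxylic acid or an amine at the end of the chain on this nitrogen would stand against the esters of compound 1 and compound 3.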